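The source may report more compounds than this note shows. Statements on the series, on what has been measured and on what is new or still open speak of the compounds shown alone.

Among the compounds with values here, compound 1 `C=CC(O)C1=CC(=O)c2ccccc2C1=O` holds the lowest of the two numbers so far: in a functional assay on WHCO1 cells (Homo sapiens) for cytotoxicity, read by MTT assay, with a stated time of 24 h (a higher number here means a weaker inhibitor, a lower number a stronger inhibitor), compound 1 gives 4300 nM. Within the data shown here, the only other measured compound, compound 2 `O=C(C1=CC(=O)c2ccccc2C1=O)c1ccccc1`, gives 63400 nM in this assay, a gap well beyond the scatter; no single-change step connects these two, so the pair shows only how far apart their values lie. Compound 3 `O=C1C=C(C(O)c2ccc(F)cc2)C(=O)c2ccccc21` has not yet been measured. It differs from compound 1 in one place: 4-fluorophenyl in place of vinyl on a saturated chain carbon bound to a double-bonded ring carbon and an oxygen on a saturated carbon. Among the measured compounds shown here, no measured pair isolates this change, so the expectation rests on compound 1 alone. A modest loss is expected, since the shared core with an oxygen on a saturated carbon is kept while only the group on that carbon changes. The step from compound 1 to compound 3 is expected to be a 1.9-fold higher number from compound 1 to compound 3 (0.27 log units; within the scatter). Compound 3 is therefore estimated at 8000 nM, with a range from 2000 nM to 35000 nM.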

Compound 3, half-maximal inhibitory concentration: 5100 nM
Estimate against measurement, compound 3: 1.6-fold (0.20 log units) above; the range from low to high includes it.
By their numbers in this assay, from the lowest: compounds 1 and 3 (each within the scatter of the next); then compound 2.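

In this assay, the new result is a 1.2-fold higher number from compound 1 to compound 3 (0.07 log units; within the scatter), so the values of these two compounds cannot be told apart. At this saturated chain carbon, then, 4-fluorophenyl, with its seven heavy atoms and six-membered aromatic ring, stands in place of vinyl, with its two heavy atoms and double bond, without a step beyond the scatter; for this pair, the vinyl double bond is not needed to keep the value within that scatter. Nothing available explains why the two groups give such close values.

The compounds shown leave open what the fluorine contributes, and what a plain phenyl, a methyl or a longer chain would give on the same carbon. They also leave open what an amine in place of the oxygen on that saturated carbon would give.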